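Swapping the amine on a shared core: compound 4

The compounds below may be only part of what the source reports. "The series", "measured", "known", "first", "only" and "open" are said of these compounds alone.

Of the compounds shown here, three built on one shared core have been tested in a functional assay on CHO-K1 cells for antagonist activity at melanin-concentrating hormone receptor 1 (Homo sapiens), read by inositol phosphate accumulation, with stated times of 10 min and 45 min; on this read-out lower numbers stand for stronger inhibition and higher numbers for weaker inhibition. Compound 1, `Cc1nc(N(C)C2CCCC2)nc2ccc(NC(=O)/C=C/c3ccc(Cl)cc3)cc12`, gives 57 nM in this assay. Compound 3, `Cc1nc(N2CCC(N3CCNC3=O)CC2)nc2ccc(NC(=O)/C=C/c3ccc(OC(F)(F)F)cc3)cc12`, gives 31 nM, and its gap to compound 1 lies within the scatter, so the two cannot be told apart. Compound 2, `C/C(=C\C(=O)Nc1ccc2nc(N3CCC(O)CC3)nc(C)c2c1)c1ccc(Cl)cc1`, gives 227 nM, a clearly higher number than compound 1, beyond the scatter. Compound 1 therefore stands second highest of the three, close to compound 3 and well apart from compound 2.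

Compound 4, `Cc1nc(N2CCC(O)(C3CCC3)CC2)nc2ccc(NC(=O)/C=C/c3ccc(Cl)cc3)cc12`, is not yet measured. It differs from compound 1 in one spot: 4-cyclobutyl-4-hydroxypiperidin-1-yl in place of cyclopentyl(methyl)amino on an aromatic carbon. Within the data shown here, compound 2 and compound 3 both carry a substituted piperidinyl group in the same position and stay in the same broad region as compound 1, though they also differ elsewhere, so no step is defined between them and compound 1.

On that basis the change is expected to be small, with no clear direction beyond the scatter, though a modest rise toward the number of compound 2 is possible. Compound 4 is estimated at 70 nM, with a range from 25 nM to 200 nM, meaning an expected step of a 1.2-fold higher number from compound 1 to compound 4 (0.09 log units; within the scatter).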

Compound 4, half-maximal inhibitory concentration: 54 nM
The estimate for compound 4 lay 1.3-fold (0.11 log units) above the measured number; the range from low to high includes it.
By their numbers in this assay, from the lowest: compounds 3, 4 and 1 (each within the scatter of the next); then compound 2.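

This is the only pair shown that differs in one place, so it gives a direct reading of this position on the shared core: in this assay, 4-cyclobutyl-4-hydroxypiperidin-1-yl in place of cyclopentyl(methyl)amino gives a 1.1-fold lower number from compound 1 to compound 4 (0.02 log units; within the scatter), and the two compounds cannot be told apart. The swap is not a small one in structure, since the entering group has more heavy atoms, a four-membered ring and a six-membered ring instead of one five-membered ring, and a hydrogen-bond donor that the leaving group lacks, yet on the aromatic carbon between two ring nitrogen atoms the number does not move beyond the scatter. Nothing available here explains why the number holds through this change.

The compounds shown do not separate the hydroxy group from the cyclobutyl group, so the contribution of each alone stays unknown. Also open, as far as these compounds go, is how a primary amine or a carboxylic acid in place of that hydroxy group would read in this assay.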